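Acetyl on the amine nitrogen of compound 3

A few compounds are considered here, and "the series" means these few. Any claim that something is new, unique, unknown or untested is made for them only; others in the source may bear on it.

The measured compounds share one core and differ only in what sits on the amine nitrogen. In a functional assay on Ehrlich cells (Mus musculus) for cytotoxicity, read by MTT assay, with a stated time of 24 h (on this read-out higher numbers stand for weaker inhibition and lower numbers for stronger inhibition), compound 1 `COc1cc(C)cc2c1C(=O)C=C(c1c(C)cc3c(c1OC)C(=O)C(NCc1ccccc1)=CC3=O)C2=O` gives 1410 nM, compound 2 `CCOC(=O)CNC1=CC(=O)c2cc(C)c(C3=CC(=O)c4c(OC)cc(C)cc4C3=O)c(OC)c2C1=O` gives 90 nM and compound 3 `COc1cc(C)cc2c1C(=O)C=C(c1c(C)cc3c(c1OC)C(=O)C(N)=CC3=O)C2=O` gives 350 nM. Compound 3 therefore holds the second highest of the three numbers, and both of its gaps lie beyond the scatter.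

Compound 4 `COc1cc(C)cc2c1C(=O)C=C(c1c(C)cc3c(c1OC)C(=O)C(NC(C)=O)=CC3=O)C2=O` carries acetyl in place of hydrogen on an amine nitrogen, which reads as amino to acetamido.

Among the compounds with values here, three measured steps bear on this change, all at the same nitrogen. The modest 4.0-fold lower number from compound 1 to compound 3 (0.61 log units; beyond the scatter) and the modest 3.9-fold higher number from compound 2 to compound 3 (0.59 log units; beyond the scatter) both end at the free amine, yet they run in opposite directions. The large 16-fold lower number from compound 1 to compound 2 (1.19 log units; beyond the scatter) shows how far apart two substituted amines can lie in this assay. Within the data shown here, no measured compound carries acetyl, so the data set no direction for this change.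

No step beyond the scatter is the central expectation, though a modest step either way remains possible. The estimate amounts to an expected 1.2-fold lower number from compound 3 to compound 4 (0.07 log units; within the scatter). For compound 4 the expected value is 300 nM, with an estimated range from 90 nM to 1200 nM.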

Compound 4, half-maximal inhibitory concentration: 60 nM
For compound 4 the middle estimate is 5.0-fold (0.70 log units) above the measured one; the measured number lies below the stated range.
By their numbers in this assay, from the lowest: compounds 4 and 2 (each within the scatter of the next); then compound 3; then compound 1.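

Acetyl in place of hydrogen on the amine nitrogen gives a 5.8-fold lower number from compound 3 to compound 4 (0.77 log units; beyond the scatter) in this assay and so sets a direction for this pair, which the earlier compounds left open. With a 1.5-fold lower number from compound 2 to compound 4 (0.18 log units; within the scatter), the acetamido compound 4 and the (ethoxycarbonyl)methyl compound 2 cannot be told apart, so the lower numbers in this set go with two different substituents on this nitrogen, each holding a carbonyl, while compound 3 with no substituent and compound 1 with benzyl sit higher. The a 24-fold lower number from compound 1 to compound 4 (1.37 log units; beyond the scatter) is now the widest step in the set, and substitution on this nitrogen is seen to lower the number relative to the free amine only for compounds 2 and 4, with compound 1 going against it.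

The data give no cause for any of these steps. Still open, from the compounds shown here alone, is whether the carbonyl is what separates these compounds, which a methyl or ethyl group on the nitrogen could test against a longer acyl chain such as propionyl or against benzoyl, the carbonyl counterpart of the benzyl in compound 1.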